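The source may report more compounds than this note shows. Statements on the series, on what has been measured and on what is new or still open speak of the compounds shown alone.

Measured compounds:
- compound 1 `CCC1(CCCCN2CCN(c3ccccc3Cl)CC2)C(=O)Nc2ccccc21`: 53 nM
- compound 2 `CCC1(CCCCN2CCN(c3ccc(Cl)cc3)CC2)C(=O)Nc2cc(F)c(Cl)cc21`: 10 nM

Both were read in an assay on CHO cells for displacement of a labelled ligand from 5-hydroxytryptamine receptor 7 (Homo sapiens), read by scintillation counting; a lower number here means a stronger inhibitor, a higher number a weaker inhibitor. Of the two numbers, compound 1 has the higher one, and compound 2 lies beyond the usual scatter from it, with the lower value. The two compounds differ at more than one place, so their gap cannot be tied to a single change.

The next compound, compound 3 `CCC1(CCCCN2CCN(c3cccc(C(F)(F)F)c3)CC2)C(=O)Nc2ccccc21`, is not yet measured. It differs from compound 1 at one place: 3-(trifluoromethyl)phenyl in place of 2-chlorophenyl on an amine nitrogen in a ring.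

Going by the values given here, no measured pair shows this change alone, so its effect on this assay is not known from the present data. Compound 1 sits mid-range on the numbers shown and the change keeps the rest of the core intact. The step of a 1.3-fold lower number from compound 1 to compound 3 (0.12 log units; within the scatter) is expected to be small, without a clear direction, and likely within the scatter. For compound 3 the estimated value is 40 nM, with a range from 12 nM to 130 nM.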

Compound 3, inhibition constant: 5.1 nM
Compound 3: middle estimate off by 7.8-fold (0.89 log units), on the high side; the whole stated range lies above it.
By their numbers in this assay, from the lowest: compounds 3 and 2 (each within the scatter of the next); then compound 1.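

In this assay, going by these compounds alone, the group on the amine nitrogen in the ring gives the first step that can be read at a single place: 3-(trifluoromethyl)phenyl in place of 2-chlorophenyl gives a 10-fold lower number from compound 1 to compound 3 (1.02 log units; beyond the scatter), with the rest of the core of compound 1 unchanged. This position therefore has a large effect on the number in this pair, which the earlier comparison of compound 1 and compound 2 could not show, as those two differ at more than one place. Nothing available bears on why the step is this large.

The change replaces the substituent and moves its place on the phenyl ring in one step, so the compounds shown leave open whether the identity of the group or its place accounts for the step. Also open, as far as these compounds go, is how a plain phenyl, a methoxyphenyl or a cyanophenyl would read on the same nitrogen, and whether the step would hold on the fluoro- and chloro-substituted core of compound 2.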